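This account rests on a few compounds, and the source may have more. Where it says the series, first, only, none or still open, it means among the compounds named here.

Measured so far:
compound 1 `CCCC(C)n1c(CC)nc2c(-c3ccc(OC(F)(F)F)cc3Cl)nccc21` — in an assay for binding affinity to Corticotropin releasing factor receptor (Rattus norvegicus) (a higher number here means a weaker inhibitor, a lower number a stronger inhibitor), compound 1 gives 2.8 nM
compound 2 `CCc1nc2c(-c3ccc(Cl)cc3C(F)(F)F)nccc2n1C(CC)C1CC1` — in this assay compound 2 gives 4.4 nM

Compound 2 and compound 1 give numbers that fall within the usual scatter of each other, so the two cannot be told apart on these data. The next compound, compound 3 `CCc1nc2c(-c3ccc(Cl)cc3C)nccc2n1C(CC)C1CC1`, differs from compound 2 in one place: methyl in place of trifluoromethyl on an aromatic carbon. Going by the values given here, no step between two measured compounds shows what such a swap does here, so the expected step of a 1.4-fold higher number from compound 2 to compound 3 (0.13 log units; within the scatter) is small, probably a slight weakening that barely exceeds the scatter. Compound 3 is therefore estimated at 6 nM, within a range from 2 nM to 20 nM.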

Compound 3, inhibition constant: 14 nM
Compound 3: middle estimate off by 2.3-fold (0.37 log units), on the low side, within the range that was stated.
By their numbers in this assay, from the lowest: compounds 1 and 2 (each within the scatter of the next); then compound 3.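

In this assay, going by these compounds alone, putting methyl in place of trifluoromethyl on this aromatic carbon, ortho to a large group, gives the first step here that lies beyond the scatter (a 3.2-fold higher number from compound 2 to compound 3 (0.50 log units; beyond the scatter)). The choice of group at this carbon therefore matters, although the size of the effect is modest and neither group has hydrogen-bond donors or acceptors. Nothing available explains this step. Going by these compounds, whether a methoxy group or a nitrile at this carbon would give a number closer to that of compound 2 stays open. One step also cannot show whether this swap acts the same way in other compounds.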